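Chloro for methyl: what is expected of compound 3

The source may report more compounds than this note shows. Statements on the series, on what has been measured and on what is new or still open speak of the compounds shown alone.

Of the compounds shown here, two sharing the same core have been measured in a functional assay on the whole organism for inhibition, with Mus musculus as the target; on this read-out lower numbers stand for an effect already at smaller amounts and higher numbers for an effect only at larger amounts of compound. Compound 1, `CCN1CCCC1CNC(=O)c1cc(N(C)S(=O)(=O)N(C)C)c(Cl)cc1OC`, gives 31.8 mg/kg in this assay. Compound 2, `CCN1CCCC1CNC(=O)c1cc(N(C)S(N)(=O)=O)c(C)cc1OC`, is a different case. In this assay compound 2 gives no number but only a limit, > 50 mg/kg. Compound 2 therefore stands at the limit of > 50 mg/kg in this assay, at which 1 of the 2 values shown sits, and the distance between its value and that of compound 1 cannot be sized from the two results. Compound 3, `CCN1CCCC1CNC(=O)c1cc(N(C)S(N)(=O)=O)c(Cl)cc1OC`, has not yet been measured. It differs from compound 2 by chloro in place of methyl on an aromatic carbon. Compound 3 shares this chloro group with compound 1 and shares the sulfamoyl part with compound 2, so both measured results bear on it, though neither settles it. Compound 3 is expected to show a step of an at least 1.2-fold lower number from compound 2 to compound 3 (0.09 log units; that floor lies within the scatter) toward smaller doses, of a size the limit on compound 2 leaves uncertain. The estimate for compound 3 in this assay is 40 mg/kg, with a range from 18 mg/kg to 90 mg/kg, and a fair chance that only a limit is reported again.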

Compound 3, dose for half-maximal effect: > 50 mg/kg
Compound 3 was reported as a limit (the forecaster's own chance of this, stated with the estimate: 40%); middle value at least 1.2-fold (0.09 log units) away from the limit.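

In this assay compound 3 gives only a limit, > 50 mg/kg, so replacing the methyl by chloro, ortho to a methyl(sulfamoyl)amino group, does not bring the amino sulfonyl series to a measured number. The size and even the direction of this change cannot be read, as the two compounds that carry it end at the same limit: the limit of > 50 mg/kg in this assay, at which 2 of the 3 values shown sit.

The new information lies in the other comparison, which holds chloro constant and changes only the group on the sulfonyl sulfur, amino in place of dimethylamino: it gives an at least 1.5-fold higher number from compound 1 to compound 3 (0.19 log units; that floor lies within the scatter), and the floor of that step does not by itself separate the two compounds from the usual scatter.

The compounds shown leave open how far compound 2 and compound 3 lie beyond the limit, and so whether chloro and methyl differ at this position at all. They also leave open how a methylamino group on the sulfonyl sulfur, or a bromo on the aromatic carbon, would read in this assay.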